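The source may report more compounds than this note shows. Statements on the series, on what has been measured and on what is new or still open speak of the compounds shown alone.

Three compounds built on one shared core were examined in a functional assay on B16-F10 cells (Mus musculus) for antiproliferative activity, read by CCK-8 assay, with a stated time of 48 h; on this read-out lower numbers stand for stronger inhibition and higher numbers for weaker inhibition. Compound 1 `COc1ccc(/C=C\c2cc(OC)c(OC)c(OC)c2)cc1OCc1ccc(CN[C@H](C(=O)O)[C@H](C)O)cc1` gives > 10000 nM in this assay, which is a limit of the assay and not a number. Compound 2 `COc1ccc(/C=C\c2cc(OC)c(OC)c(OC)c2)cc1OCc1ccc(CN2CC(C(=O)O)C2)cc1` gives > 10000 nM in this assay, again only a limit. Compound 3 `COc1ccc(/C=C\c2cc(OC)c(OC)c(OC)c2)cc1OCc1ccc(CN2CCCC[C@H]2C(=O)O)cc1` gives > 10000 nM in this assay, once more a limit. Compound 2 thus stands where every measured value in this set stands, namely at the limit of > 10000 nM in this assay, at which 3 of the 3 values shown sit. Going by the values given here, the step that the two limits leave unreadable from compound 1 to compound 2 and the step that the two limits leave unreadable from compound 2 to compound 3 are both concealed by these limits, so no measured step reveals how compound 2 responds to a change at this position.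

The unmeasured compound 4 `COc1ccc(/C=C\c2cc(OC)c(OC)c(OC)c2)cc1OCc1ccc(CNCCNC(C)=O)cc1` differs from compound 2 by (2-acetamidoethyl)amino in place of 3-carboxyazetidin-1-yl on a saturated chain carbon bound to an aromatic carbon. The two steps that touch compound 2 are the only ones that bear on this change, and neither has a readable size, so no direction can be drawn from them. With every measured value a limit, the expectation for compound 4 is that it also sits near the limit, estimated at 8000 nM with a range from 1000 nM to 30000 nM. The step of an at least 1.2-fold lower number from compound 2 to compound 4 (0.09 log units; that floor lies within the scatter) is therefore expected to be small or unreadable.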

Compound 4, half-maximal inhibitory concentration: 2500 nM
For compound 4 the middle estimate is 3.2-fold (0.51 log units) above the measured one, and the stated range covers the measured number.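

In this assay, going by these compounds alone, this position turns out not to be silent: the saturated chain carbon bound to an aromatic carbon can carry a group that gives a readable value, which none of the earlier compounds showed. The change from 3-carboxyazetidin-1-yl to (2-acetamidoethyl)amino gives an at least 4.0-fold lower number from compound 2 to compound 4 (0.60 log units; beyond the scatter), the change from 2-carboxypiperidin-1-yl gives an at least 4.0-fold lower number from compound 3 to compound 4 (0.60 log units; beyond the scatter), and the change on the amine nitrogen gives an at least 4.0-fold lower number from compound 1 to compound 4 (0.60 log units; beyond the scatter), each a floor set by a limit, while the steps among compound 1, compound 2 and compound 3 cannot be read. Among the compounds shown, all three that carry a carboxy group stay at one limit and compound 4, which carries none, is the only one to leave it, with no compound going against this split: the limit of > 10000 nM in this assay, at which 3 of the 4 values shown sit.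

Compound 4 differs from the others in several features at once, so the compounds shown leave open whether the step goes with the loss of the carboxylic acid, the open chain or the acetamide. On these data alone, a methyl ester of the acid, a simple amine or a longer chain ending in the acetamide would separate these, and the true size of each step also remains open.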